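Benzyl for phenyl on selenium in a quinoline ester series

A few compounds are considered here, and "the series" means these few. Any claim that something is new, unique, unknown or untested is made for them only; others in the source may bear on it.

Three compounds sharing one core were measured in a functional assay on SK-MEL-147 cells (Homo sapiens) for cytotoxicity, read by MTT assay, with a stated time of 24 h; on this read-out lower numbers stand for an effect already at smaller amounts and higher numbers for an effect only at larger amounts of compound. Compound 1 `CCCCC#Cc1cc(C(=O)OCC)nc2ccc(OC)cc12` gives 7200 nM; compound 2 `CCOC(=O)c1cc([Se]c2ccccc2C)c2cc(OC)ccc2n1` gives 38900 nM; compound 3 `CCOC(=O)c1cc([Se]c2ccccc2)c2cc(Br)ccc2n1` gives 12400 nM. Among the measured compounds shown here, the only single-change step among them, a 5.4-fold higher number from compound 1 to compound 2 (0.73 log units; beyond the scatter), concerns a different part of the molecule. Compound 3 stands second highest of the three numbers, within the scatter of compound 1 and beyond the scatter of compound 2. Compound 4 `CCOC(=O)c1cc([Se]Cc2ccccc2)c2cc(Br)ccc2n1` differs from compound 3 by benzyl in place of phenyl on a selenium. For the measured compounds named here, no measured step exchanges these two groups on a selenium, so nothing in this assay argues for a change beyond the scatter. Compound 4 is therefore expected near its parent, with no change at the digits printed from compound 3 to compound 4 (within the scatter), estimated at 12400 nM in a range from 5000 nM to 31000 nM.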

Compound 4, half-maximal effective concentration: 31200 nM
Estimate against measurement, compound 4: 2.5-fold (0.40 log units) below, and the stated range ends below it.
By their numbers in this assay, from the lowest: compounds 1 and 3 (each within the scatter of the next); then compounds 4 and 2 (each within the scatter of the next).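

In this assay, among the compounds shown here, the first measured exchange on this selenium, benzyl in place of phenyl, gives a 2.5-fold higher number from compound 3 to compound 4 (0.40 log units; beyond the scatter). The group on the selenium therefore matters in this assay, although both groups carry one six-membered aromatic ring of carbon only and neither has hydrogen-bond donors or acceptors. Nothing measured here explains the step.

The compounds shown leave open whether a longer chain between the selenium and the ring would continue this trend. They also leave open how an amine or a carboxylic acid on that ring would behave.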